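The source may hold more compounds than are shown below. What is called first, only, known or untested is meant among the compounds shown, and "the series" means these compounds.

Measured so far:
compound 1 `CCCCC(=O)O[C@@H]1CO[C@H]2[C@@H]1OC[C@@H]2OC(=O)c1ccccc1OC(C)=O`: 0.0117 h
compound 2 `CC(=O)Oc1ccccc1C(=O)O[C@H]1CO[C@H]2[C@@H]1OC[C@H]2O[N+](=O)[O-]`: 0.00314 h

In an ADME assay on a cell-free system (plasma, Homo sapiens) for metabolic stability, with Plasma (Rattus norvegicus) as the target, read by HPLC, at pH 7.4 (a higher number here means that the compound lasts longer, a lower number that the compound disappears faster), compound 1 stands highest of the two numbers; compound 2 gives a lower value, the step being a 3.7-fold lower number from compound 1 to compound 2 (0.57 log units; beyond the scatter). Compound 3 `CC(=O)Oc1ccccc1C(=O)O[C@H]1CO[C@H]2[C@@H]1OC[C@H]2OC(=O)CCO[N+](=O)[O-]` keeps the shared core of compound 1 and differs only by nitrooxy in place of ethyl on a saturated chain carbon, two bonds along the chain from a carbonyl carbon, the butylcarbonyl becoming (2-(nitrooxy)ethyl)carbonyl. Among the compounds with values here, only the step from compound 1 to compound 2 bears on this, and there the nitro replaced the whole butylcarbonyl, so its bearing is loose. A modest decrease is expected. Compound 3 is estimated at 0.008 h, within 0.003 h to 0.02 h. The expected step is a 1.5-fold lower number from compound 1 to compound 3 (0.17 log units; within the scatter).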

Compound 3, half-life: 0.0217 h
Compound 3: middle estimate off by 2.7-fold (0.43 log units), on the low side, outside the stated range (above it).
By their numbers in this assay, from the lowest: compound 2; then compounds 1 and 3 (each within the scatter of the next).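

In this assay, nitrooxy in place of ethyl on a saturated chain carbon, two bonds along the chain from a carbonyl carbon, gives a 1.9-fold higher number from compound 1 to compound 3 (0.27 log units; within the scatter) and so stays within the scatter at this position. With (2-(nitrooxy)ethyl)carbonyl in place of nitro on the oxygen, the result is a 6.9-fold higher number from compound 2 to compound 3 (0.84 log units; beyond the scatter) and so a nitro group in the molecule does not by itself bring the low number of compound 2. Nothing at hand accounts for either step. On these data alone, whether a longer chain before the nitrooxy, or an amine in its place, would move the number beyond the scatter remains open.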